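A few compounds are considered here, and "the series" means these few. Any claim that something is new, unique, unknown or untested is made for them only; others in the source may bear on it.

Working notes on the series. Of the compounds shown here, two have numbers so far. Compound 1 `O=C(CN1CCN(S(=O)(=O)c2ccc(F)cc2)CC1)Nc1ccccc1` gives 18500 nM in an in vitro assay on HEK ts201 cells for negative allosteric modulation of Neuronal acetylcholine receptor; alpha3/beta4 (Homo sapiens), read by fluorescence and calcium flux, with a stated time of 1.5 s; on this read-out higher numbers stand for weaker inhibition and lower numbers for stronger inhibition. Compound 2 `O=C(CN1CCN(S(=O)(=O)c2ccccc2)CC1)Nc1ccccc1F` gives 4000 nM in this assay, the lowest of the two numbers; compound 1 sits a good way higher, a gap beyond the scatter. Within the data shown here, compounds 1 and 2 differ in two places at once, so no single step between measured compounds can be read from them.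

Compound 3 `O=C(CN1CCN(S(=O)(=O)c2ccccc2)CC1)Nc1ccccc1` is the next point. It differs from compound 2 only in hydrogen in place of fluoro on an aromatic carbon, giving the unsubstituted shared core. Among the measured compounds shown here, with no measured step for this change, the expectation rests on the low value of compound 2 and the higher value of compound 1 alone. Removing the fluoro is expected to move the number up, with an estimated step in this assay of a 2.0-fold higher number from compound 2 to compound 3 (0.30 log units; within the scatter). Compound 3 is therefore estimated at 8000 nM in this assay, with a range of 3000 nM to 25000 nM.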

Compound 3, half-maximal inhibitory concentration: 16400 nM
For compound 3 the middle estimate is 2.1-fold (0.31 log units) below the measured one, within the range that was stated.
By their numbers in this assay, from the lowest: compound 2; then compounds 3 and 1 (each within the scatter of the next).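

With a 4.1-fold higher number from compound 2 to compound 3 (0.61 log units; beyond the scatter) in this assay, the 2-fluorophenyl to phenyl change, hydrogen in place of fluoro on an aromatic carbon ortho to a large group, now has a measured size, and it weakens inhibition beyond the scatter. With a 1.1-fold lower number from compound 1 to compound 3 (0.05 log units; within the scatter) the same exchange at the fluoro of compound 1 stays within the scatter, so the fluoro does not count equally at both places and only the place in compound 2 shows a step that can be read as real. Nothing measured on these compounds accounts for that difference between the two places.

Still open, as far as these compounds go, is whether the step is tied to fluoro itself, or whether chloro, methyl or methoxy at the same aromatic carbon would give a comparable number. The compounds shown also leave open how a fluoro at any other carbon of that ring would read.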